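A few compounds are considered here, and "the series" means these few. Any claim that something is new, unique, unknown or untested is made for them only; others in the source may bear on it.

In a functional assay on MGC-803 cells (Homo sapiens) for inhibition, read by sulforhodamine B assay (on this read-out lower numbers stand for stronger inhibition and higher numbers for weaker inhibition), compound 1 `O=C1C=C(Nc2ccc(I)cc2)C(=O)c2c1nc1n2[C@H]2OC[C@@H](O)[C@H]2OC1` gives 1400 nM. For the measured compounds named here, compound 2 `CCc1ccc(NC2=CC(=O)c3nc4n(c3C2=O)[C@H]2OC[C@@H](O)[C@H]2OC4)cc1` gives 1290 nM, the lower of the two numbers so far, though its gap to compound 1 lies within the scatter. Going by the values given here, the single known step, a 1.1-fold lower number from compound 1 to compound 2 (0.04 log units; within the scatter), changed nothing beyond the scatter. Compound 3 `O=C1C=C(Nc2ccc(C(F)(F)F)cc2)C(=O)c2c1nc1n2[C@H]2OC[C@@H](O)[C@H]2OC1` carries trifluoromethyl in place of ethyl on an aromatic carbon. Among the compounds with values here, only a 1.1-fold lower number from compound 1 to compound 2 (0.04 log units; within the scatter) bears on this change, being the one other exchange of a group on that aromatic carbon, and it stayed within the scatter. For compound 3 the expectation is therefore a 1.0-fold higher number from compound 2 to compound 3 (0.00 log units; within the scatter), neither direction beyond the scatter. Compound 3 is estimated at 1300 nM, within 600 nM to 2800 nM.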

Compound 3, half-maximal inhibitory concentration: 2820 nM
Compound 3: middle estimate off by 2.2-fold (0.34 log units), on the low side; the whole stated range lies below it.
By their numbers in this assay, from the lowest: compounds 2, 1 and 3 (each within the scatter of the next, the first and the last beyond it).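

Exchanges on this aromatic carbon are not all silent: trifluoromethyl in place of ethyl gives a 2.2-fold higher number from compound 2 to compound 3 (0.34 log units; beyond the scatter), the first step in the series beyond the scatter, though a modest one. Trifluoromethyl in place of iodo gives a 2.0-fold higher number from compound 1 to compound 3 (0.30 log units; within the scatter), so only the comparison with ethyl separates trifluoromethyl from another group at this position. No measurement shown accounts for the step.

From the compounds shown here alone, whether an amine, a carboxylic acid or a longer chain on this carbon would move the number further, and in which direction, remains open.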